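Removing a methoxy group from a fused core

This account rests on a few compounds, and the source may have more. Where it says the series, first, only, none or still open, it means among the compounds named here.

Measured compounds:
compound 1, `Fc1ccc(/C=C/c2cc3ccccc3nc2Cl)cc1`: 120 nM
compound 2, `COc1ccc2nc(Cl)c(/C=C/c3ccc(F)cc3)cc2c1`: 14800 nM
compound 3, `COc1ccc2nc(Cl)c(/C=C\c3cc(C(F)(F)F)cc(C(F)(F)F)c3)cc2c1`: 5790 nM

Of the compounds shown here, three have been measured in a functional assay on MDA-MB-468 cells (Homo sapiens) for antiproliferative activity, read by sulforhodamine B assay, with a stated time of 72 h; a lower number here means a stronger inhibitor, a higher number a weaker inhibitor. Compound 1 gives 120 nM, while compound 2, carrying a methoxy group on its core, gives 14800 nM. The difference is hydrogen in place of methoxy on an aromatic carbon, and the step it made is a 120-fold lower number from compound 2 to compound 1 (2.09 log units; beyond the scatter). Compound 3 gives 5790 nM in this assay; the difference between its core and that of compound 2 is not broken down here.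

Compound 4, `FC(F)(F)c1cc(/C=C\c2cc3ccccc3nc2Cl)cc(C(F)(F)F)c1`, has not yet been measured. It differs from compound 3 by hydrogen in place of methoxy on an aromatic carbon, the same change as from compound 2 to compound 1. For compound 4 the expected step is a 58-fold lower number from compound 3 to compound 4 (1.76 log units; beyond the scatter), resting on the earlier step of a 120-fold lower number from compound 2 to compound 1 (2.09 log units; beyond the scatter), though its size is known from one pair only and compound 3 carries a different aryl part. Compound 4 is therefore estimated at 100 nM, within 20 nM to 600 nM.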

Compound 4, half-maximal inhibitory concentration: 10500 nM
Beside the measured number, compound 4's estimate is 110-fold (2.02 log units) below it; the whole stated range lies below it.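

In this assay, the exchange of methoxy for hydrogen gives a 1.8-fold higher number from compound 3 to compound 4 (0.26 log units; within the scatter), and this step does not match the earlier one: the same change on two cores in this assay, a 120-fold lower number (2.09 log units; beyond the scatter) from compound 2 to compound 1 and a 1.8-fold higher number (0.26 log units; within the scatter) from compound 3 to compound 4, 220-fold (2.35 log units) apart, beyond the scatter of two such steps. The large step seen on the first pair therefore did not carry over to the second, so in this series the size of this change cannot be taken from one pair and applied to another. It does not show what sets the two pairs apart, since they differ in both the aryl part and the geometry of the double bond, and two pairs give no rule for any other compound.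

The compounds shown leave open whether the aryl part or the double-bond geometry decides the outcome of removing the methoxy group. They also leave open what a hydroxyl group, an amine or a longer ether chain would do in place of the methoxy group on either pair.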